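A few compounds are considered here, and "the series" means these few. Any claim that something is new, unique, unknown or untested is made for them only; others in the source may bear on it.

Going by the values given here, in a functional assay on SK-OV-3 cells (Homo sapiens) for antiproliferative activity, read by MTT assay, with a stated time of 24 h (a higher number here means a weaker inhibitor, a lower number a stronger inhibitor), compound 2 `COc1ccc(C(=O)/C=C/c2cccc([N+](=O)[O-])c2)c2c1C=CC(C)(C)O2` gives 9720 nM, the only true number so far. Compound 1 `COc1ccc(C(=O)/C=C/c2cccc(F)c2)c2c1C=CC(C)(C)O2` reads > 10000 nM, which is a limit of the assay. Compound 3 `COc1ccc(C(=O)/C=C/c2cccc(C(F)(F)F)c2)c2c1C=CC(C)(C)O2` differs from compound 2 by trifluoromethyl in place of nitro on an aromatic carbon. Among the compounds with values here, the only measured guide is the nitro in place of fluoro change at the same place, an at least 1.0-fold lower number from compound 1 to compound 2 (0.01 log units; that floor lies within the scatter), and it gives a floor, not a size. The expected change, a 1.0-fold higher number from compound 2 to compound 3 (0.01 log units; within the scatter), therefore stays within the scatter, with no direction favoured. For compound 3 the estimate is 10000 nM, with an expected range of 5000 nM to 20000 nM.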

Compound 3, half-maximal inhibitory concentration: 9330 nM
Compound 3: the middle estimate sits 1.1-fold (0.03 log units) above what was measured, and the stated range covers the measured number.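

Trifluoromethyl in place of nitro, on this aromatic carbon meta to a large group, gives no readable change in this assay (a 1.0-fold lower number from compound 2 to compound 3 (0.02 log units; within the scatter)), although the two groups differ in their counted hydrogen-bond acceptors. The step from the fluoro compound (an at least 1.0-fold lower number from compound 1 to compound 3 (0.03 log units; that floor lies within the scatter)) gives only a floor. Compound 1 remains a limit of the assay: the limit of > 10000 nM in this assay, at which 1 of the 3 values shown sits.

Going by these compounds, whether an amine or a carboxylic acid on this carbon would move the number beyond the scatter stays open. So does the effect of nitro or trifluoromethyl on any other carbon of this ring.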